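Compound 4 in the WI-38 cytotoxicity assay

The source may hold more compounds than are shown below. What is called first, only, known or untested is meant among the compounds shown, and "the series" means these compounds.

Measured in an ADME assay on WI-38 cells (Homo sapiens) for cytotoxicity, read by MTT assay, with a stated time of 72 h; a lower number here means a stronger inhibitor, a higher number a weaker inhibitor:
Compound 1 `O=C(CCc1cccc2c1B(O)OC2)NC1CCCCC1`: > 100000 nM, a limit
Compound 2 `O=C(CCc1cccc2c1B(O)OC2)Nc1ccc(Cl)cc1`: > 100000 nM, a limit
Compound 3 `O=C(CCc1cccc2c1B(O)OC2)Nc1ccc(I)cc1`: 49000 nM

Among the compounds with values here, compound 3 gives the only true number in this assay, and the other two compounds stand at the limit of > 100000 nM in this assay, at which 2 of the 3 values shown sit. Compound 4 `O=C(CCc1cccc2c1B(O)OC2)Nc1cccc(Br)c1` differs from compound 3 in one place, with 3-bromophenyl in place of 4-iodophenyl on an amide-type nitrogen. Within the data shown here, two measured steps bear on this change, an at least 2.0-fold lower number from compound 2 to compound 3 (0.30 log units; that floor lies within the scatter) and an at least 2.0-fold lower number from compound 1 to compound 3 (0.30 log units; that floor lies within the scatter), and the floor of each lies within the scatter. Compound 4 loses the iodo group, which is the group gained in the step of an at least 2.0-fold lower number from compound 2 to compound 3 (0.30 log units; that floor lies within the scatter), so a small move toward a higher number is expected. The expected step is a 1.5-fold higher number from compound 3 to compound 4 (0.18 log units; within the scatter). For compound 4 the estimate is 75000 nM, with an expected range from 35000 nM to 150000 nM.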

Compound 4, half-maximal inhibitory concentration: 20000 nM
Beside the measured number, compound 4's estimate is 3.8-fold (0.57 log units) above it, and the stated range ends above it.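

In this assay, the step of a 2.5-fold lower number from compound 3 to compound 4 (0.39 log units; beyond the scatter) is the only one here between two true numbers, and it lies beyond the scatter, so the group on the amide-type nitrogen does move this read-out. The steps of an at least 5.0-fold lower number from compound 2 to compound 4 (0.69 log units; beyond the scatter) and an at least 5.0-fold lower number from compound 1 to compound 4 (0.69 log units; beyond the scatter) also lie beyond the scatter, but each is only a floor: the limit of > 100000 nM in this assay, at which 2 of the 4 values shown sit. The change swaps the halogen and moves it on the phenyl ring in one go, so the compounds shown do not separate these two changes. As far as these compounds go, how an amine or a carboxylic acid on that phenyl ring would read remains open.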